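A few compounds are considered here, and "the series" means these few. Any claim that something is new, unique, unknown or untested is made for them only; others in the source may bear on it.

Measured compounds:
- compound 1, `O=C(O)/C(O)=C/C(=O)c1ccc(OCc2ccc(Cl)cc2)cc1`
- compound 2, `O=C(O)/C(O)=C/C(=O)c1cccc(OCc2ccccc2)c1`

In an ADME assay on Huh-7 cells (Homo sapiens) for cytotoxicity (on this read-out higher numbers stand for lower toxicity in this test and lower numbers for higher toxicity in this test), compound 1 gives > 100000 nM, which is a limit of the assay and not a number. In this assay compound 2 gives > 100000 nM, again a limit rather than a number. Compound 2 therefore stands where both values shown sit, at the limit of > 100000 nM in this assay, at which 2 of the 2 values shown sit; nothing sets it apart from compound 1 on the numbers available.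

Compound 3 `O=C(O)/C(O)=C/C(=O)c1cccc(OCc2ccc(Cl)cc2)c1` is not yet measured. It differs from compound 2 by chloro in place of hydrogen on an aromatic carbon, para to a large group. Within the data shown here, no step between measured compounds exists, so the size of the change must be judged from the two limits alone. For compound 3 no step beyond the scatter is expected in this assay, and the estimated step is a number no higher from compound 2 to compound 3 (the limit leaves the size open). Compound 3 is expected to give 100000 nM, in a range of 50000 nM to 200000 nM, most likely again reported only as a limit.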

Compound 3, half-maximal cytotoxic concentration: > 100000 nM
Compound 3 ended at the assay's limit; the forecaster's own chance of this, stated with the estimate: 80%; the middle value sits exactly at the limit.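

In this assay compound 3 gives > 100000 nM, a limit of the assay and not a number. With compound 2 also at a limit, no step can be read between compound 2 and compound 3. The compounds shown leave open whether chloro in place of hydrogen on an aromatic carbon changes the read-out in this assay.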